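The compounds below may be only part of what the source reports. "The series", "measured", "known", "first", "only" and "open" are said of these compounds alone.

Measured compounds in an assay on membranes from CHO cells for displacement of a labelled ligand from adenosine receptor A1 (Homo sapiens), read by scintillation counting, with a stated time of 60 min, tested at 1 uM; a lower number here means less inhibition, a higher number more inhibition at the concentration tested (going by the name of the read-out):
Compound 1, `CC1=C(C(=O)NC(C)C)C(c2ccco2)NC(=O)N1`: 3%
Compound 2, `CCN(CC)C(=O)C1=C(C)NC(=O)NC1c1ccco1`: 11%
Compound 3, `CC1=C(C(=O)NC(C)C)C(c2ccoc2)NC(=O)N1`: 1%

Among the measured compounds shown here, all three sit low in this assay, and no step among them goes beyond the scatter. From compound 1 to compound 2 the change is diethylamino in place of isopropylamino on a carbonyl carbon, and it gave a number 8 percentage points higher from compound 1 to compound 2 (within the scatter). The cores of compound 1 and compound 3 differ in that (furan-3-yl in place of furan-2-yl on a saturated ring carbon), with a number 2 percentage points lower from compound 1 to compound 3 (within the scatter).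

Compound 4, `CCN(CC)C(=O)C1=C(C)NC(=O)NC1c1ccoc1`, is not yet measured. For the measured compounds named here, it is reached from compound 3 by diethylamino in place of isopropylamino on a carbonyl carbon, the same change as the one from compound 1 to compound 2, at the same place. For compound 4 a step of a number 7 percentage points higher from compound 3 to compound 4 (within the scatter) is expected. This rests on a number 8 percentage points higher from compound 1 to compound 2 (within the scatter), a step within the scatter, so little movement is expected. Compound 4 is estimated at 8% in this assay, between 0% and 20%.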

Compound 4, a percentage reported as inhibition, at one concentration (the size of the read-out at that concentration, not a potency): 15%
Estimate against measurement, compound 4: 7 percentage points below, within the range that was stated.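

In this assay, diethylamino in place of isopropylamino on a carbonyl carbon gives a number 14 percentage points higher from compound 3 to compound 4 (beyond the scatter), and this step does not differ from the one on the other core: the same change on two cores in this assay, a number 8 percentage points higher (within the scatter) from compound 1 to compound 2 and a number 14 percentage points higher (beyond the scatter) from compound 3 to compound 4, 6 percentage points apart, within the scatter of two such steps. Furan-3-yl in place of furan-2-yl on a saturated ring carbon gives a number 4 percentage points higher from compound 2 to compound 4 (within the scatter), and it too carries between the cores without a difference that can be told apart: the same change on two cores in this assay, a number 2 percentage points lower (within the scatter) from compound 1 to compound 3 and a number 4 percentage points higher (within the scatter) from compound 2 to compound 4, 6 percentage points apart, within the scatter of two such steps. This supports carrying either change between these two cores only; it shows no general rule for the series, and a read-out at one concentration gives no potency.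

Open, from the compounds shown here alone, is how a cyclic amine such as piperidine would read in place of diethylamino on the carbonyl carbon. Also open, going by these compounds, is how a phenyl ring would read in place of the furan groups.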